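The compounds below may be only part of what the source reports. "The series", "measured", "known", "first", "only" and "open" are said of these compounds alone.

Four compounds share a long chain that joins two aromatic parts, and they differ in the ring system at one end and in the group attached to it. Compound 1 `CC(C)NC(=N)c1ccc2oc(-c3cccc(OCCCCCOc4ccccc4)c3)cc2c1` carries a group of 6 heavy atoms on an aromatic carbon of the shared core, and in an ADME assay on L6 cells (Rattus norvegicus) for cytotoxicity, read by resazurin assay, with a stated time of 70 h (on this read-out higher numbers stand for weaker inhibition and lower numbers for stronger inhibition), compound 1 gives 10100 nM. Compound 2 `c1ccc(OCCCCCOc2cccc(-c3cc4cc(C5=NCCN5)ccc4o3)c2)cc1` differs from it by one exchange: a group of 5 heavy atoms (3 carbon, 2 nitrogen; one five-membered non-aromatic ring with 2 hetero atoms) in place of a group of 6 heavy atoms (4 carbon, 2 nitrogen; no ring), on an aromatic carbon. In this assay compound 2 gives 2600 nM. That exchange produced a 3.9-fold lower number from compound 1 to compound 2 (0.59 log units; beyond the scatter).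

Compound 3 `CC(C)NC(=N)c1ccc2cc(-c3ccc(OCCCCCOc4ccccc4)cc3)oc2c1` has the same atoms as compound 1, joined differently; the difference between the two cores is not broken down here. In this assay compound 3 gives 10700 nM, which sits close to the value of compound 1. Compound 4 `c1ccc(OCCCCCOc2ccc(-c3cc4ccc(C5=NCCN5)cc4o3)cc2)cc1` is not yet measured. It is related to compound 3 by the same change that turns compound 1 into compound 2: a group of 5 heavy atoms (3 carbon, 2 nitrogen; one five-membered non-aromatic ring with 2 hetero atoms) in place of a group of 6 heavy atoms (4 carbon, 2 nitrogen; no ring), on an aromatic carbon. The place is the same in both pairs, so this is the same change, made on a different core.

Because compound 1 gives 10100 nM and compound 3 gives 10700 nM, and because the exchange gave a 3.9-fold lower number from compound 1 to compound 2 (0.59 log units; beyond the scatter), the step from compound 3 to compound 4 in this assay is expected to be about a 4.0-fold lower number from compound 3 to compound 4 (0.60 log units; beyond the scatter). On that basis compound 4 is estimated to give roughly 2700 nM in this assay, plausibly between 1300 nM and 6000 nM.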

Compound 4, half-maximal inhibitory concentration: 3200 nM
Compound 4: middle estimate off by 1.2-fold (0.07 log units), on the low side; the range from low to high includes it.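

In this assay, replacing the open-chain group of 6 heavy atoms with the five-membered non-aromatic ring of 5 heavy atoms gives a 3.3-fold lower number from compound 3 to compound 4 (0.52 log units; beyond the scatter), so on this second core too the cells respond to a lower concentration of the ring-bearing compound. Set beside the first pair, the step has much the same size on both cores, so in this series the change carries over from one core to the other: the same change on two cores in this assay, a 3.9-fold lower number (0.59 log units; beyond the scatter) from compound 1 to compound 2 and a 3.3-fold lower number (0.52 log units; beyond the scatter) from compound 3 to compound 4, 1.2-fold (0.07 log units) apart, within the scatter of two such steps. Within the data shown here, this rests on only two pairs in one cell assay, so it does not show that the step would keep its size on any further core, and it does not explain why the number falls.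

Still open, going by these compounds, is whether an amine or a carboxylic acid on the same aromatic carbon would move the number in the same direction, or by a similar amount. Also open, on these data alone, is what a longer chain between the two aromatic parts would do to this step, as all four compounds share the same chain.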